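A few compounds are considered here, and "the series" means these few. Any claim that something is new, unique, unknown or untested is made for them only; others in the source may bear on it.

Measured so far:
- compound 1 `O=C(CCN1CCCCC1)N1CCC2(N3CCCCC3)CC(c3ccccc3)C1C(c1ccccc1)C2` — in an ADME assay on L6 cells (Rattus norvegicus) for cytotoxicity (on this read-out lower numbers stand for stronger inhibition and higher numbers for weaker inhibition), compound 1 gives 63900 nM
- compound 2 `CN(C)C12CC(NCCN3CCCC3)C(C(c3ccccc3)C1)C(c1ccccc1)C2` — in this assay compound 2 gives 22800 nM
- compound 3 `CN(C)C12CCN(C(=O)CCN3CCCCC3)C(C(c3ccccc3)C1)C(c1ccccc1)C2` — in this assay compound 3 gives 128000 nM

Compound 2 gives the lowest number of the three, and its steps to compound 1 and to compound 3 lie beyond the scatter. Compound 3 and compound 1 share a core; the difference between the cores of compound 2 and compound 3 is not broken down here.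

From compound 3 to compound 1 the change is piperidin-1-yl in place of dimethylamino on a saturated ring carbon, and it brought a 2.0-fold lower number from compound 3 to compound 1 (0.30 log units; within the scatter). Compound 4 `c1ccc(C2CC3(N4CCCCC4)CC(NCCN4CCCC4)C2C(c2ccccc2)C3)cc1` has not yet been measured. It differs from compound 2 by piperidin-1-yl in place of dimethylamino on a saturated ring carbon. Among the measured compounds shown here, this is the same kind of change as the one from compound 3 to compound 1, but the surroundings are not identical: in compound 3 the ring atom carrying the change is flanked by two ring atoms that each bear a phenyl group, whereas in compound 2 one neighbouring ring atom bears a (2-(pyrrolidin-1-yl)ethyl)amino group and the other a phenyl group.

Because the earlier step of a 2.0-fold lower number from compound 3 to compound 1 (0.30 log units; within the scatter) was small, the expectation for compound 4 is a similarly small movement, a 1.5-fold lower number from compound 2 to compound 4 (0.18 log units; within the scatter), from the value of compound 2 in this assay. For the measured compounds named here, with the surroundings differing and only one prior example, the estimate for compound 4 is 15000 nM, expected to fall between 6000 nM and 40000 nM.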

Compound 4, half-maximal inhibitory concentration: 27000 nM
Beside the measured number, compound 4's estimate is 1.8-fold (0.26 log units) below it; the measured number falls inside the stated range.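

In this assay, piperidin-1-yl in place of dimethylamino on a saturated ring carbon gave a 1.2-fold higher number from compound 2 to compound 4 (0.07 log units; within the scatter), so on this core the swap produced no movement that can be told apart from the ordinary spread of repeat measurements. Set beside the earlier example on the other core, the new step does not differ from it by more than that spread allows: the same change on two cores in this assay, a 2.0-fold lower number (0.30 log units; within the scatter) from compound 3 to compound 1 and a 1.2-fold higher number (0.07 log units; within the scatter) from compound 2 to compound 4, 2.4-fold (0.38 log units) apart, within the scatter of two such steps What this shows is that, across these two cores, the change travels without a readable effect on the number, but it rests on just two pairs of compounds, both steps are small, and neither establishes a direction, so it is no rule for other cores in the series or for other read-outs.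

The compounds shown leave open whether a different amine on that same saturated ring carbon, such as morpholin-4-yl or a plain primary amino group, would also leave the number where it is. They also leave open what would happen on the core of compound 2 if the (2-(pyrrolidin-1-yl)ethyl)amino group gave way to a longer chain ending in the same amine or to a chain ending in a carboxylic acid.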